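This account rests on a few compounds, and the source may have more. Where it says the series, first, only, none or still open, it means among the compounds named here.

Three compounds of the series have been run in an ADME assay on HCT-116 cells (Homo sapiens) for cytotoxicity, read by CellTiter-Glo, with a stated time of 72 h (on this read-out higher numbers stand for weaker inhibition and lower numbers for stronger inhibition), and all three return only the upper limit of the read-out. Compound 1 `CC1CCN(C2CCN(S(=O)(=O)c3cccc(N)c3)CC2)CC1` reports a limit, > 5000 nM. Compound 2 `CC1CCN(C2CCN(S(=O)(=O)c3ccc(Br)cc3OC(F)(F)F)CC2)CC1` likewise reports a limit, > 5000 nM. Compound 3 `Cc1ccc(C2CCN(S(=O)(=O)c3c(C)cc(C)cc3C)CC2)cc1` also gives only a limit, > 5000 nM. On the numbers shown, compound 3 therefore stands at the limit of > 5000 nM in this assay, at which 3 of the 3 values shown sit; it cannot be ordered against compound 1 or compound 2, since none of the three yields a number. Compound 4 `Cc1cc(C)c(S(=O)(=O)N2CCC(N3CCC(C)OC3)CC2)c(C)c1` differs from compound 3 at a single place: a group of 7 heavy atoms (5 carbon, 1 nitrogen, 1 oxygen; one six-membered non-aromatic ring with 2 hetero atoms) in place of a group of 7 heavy atoms (7 carbon; one six-membered aromatic ring of carbon only), on a saturated ring carbon. Among the measured compounds shown here, no step between measured compounds exists against which the size of this change could be gauged, so the expectation rests on the limits alone. The step that the limit leaves unreadable from compound 3 to compound 4 is expected to stay within the scatter, most likely with compound 4 again reaching only a limit in this assay. Compound 4 is estimated at 10000 nM, with a range from 5000 nM to 30000 nM.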

Compound 4, half-maximal inhibitory concentration: > 5000 nM
Compound 4 ended at the assay's limit; the forecaster's own chance of this, stated with the estimate: 85%; the middle value does not contradict the limit.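

Compound 4, like compound 3, returns only a limit, so no step between the two can be read: the limit of > 5000 nM in this assay, at which 4 of the 4 values shown sit.

The compounds shown leave open at what concentration any of them would register in this assay, and so what replacing 4-methylphenyl changes there.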